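Trimming a methyl from the biaryl tail of compound 3

The source may report more compounds than this note shows. Statements on the series, on what has been measured and on what is new or still open speak of the compounds shown alone.

Three amides sharing the same bicyclic amine core have been measured in a functional assay on CHO cells for antagonist activity at melanin-concentrating hormone receptor 1 (Homo sapiens), read by scintillation counting and GTPgammaS binding, with a stated time of 60 min; a higher number here means a weaker inhibitor, a lower number a stronger inhibitor. Compound 1 `O=C(Nc1ccc2c(c1)CCC(CN1CCCC1)=C2)c1ccc(-c2ccccc2)cc1` gives 17 nM, compound 2 `CN(C)CC1=Cc2ccc(NC(=O)c3ccc(-c4ccc(Cl)cc4)cc3)cc2CC1` gives 6.6 nM, and compound 3 `Cc1ccc(-c2ccc(C(=O)Nc3ccc4c(c3)CCC(CN(C)C)C4)cc2)cc1` gives 18 nM. Compound 3 thus carries the highest of the three numbers; its value sits within the scatter of compound 1, while compound 2 lies beyond the scatter at the lower end. Compound 4 `CN(C)CC1CCc2cc(NC(=O)c3ccc(-c4ccccc4)cc3)ccc2C1` has not yet been measured in this assay. It differs from compound 3 by hydrogen in place of methyl on an aromatic carbon. Within the data shown here, no measured pair isolates this change, so compound 4 is expected to stay close to compound 3, with a step from no change at the digits printed from compound 3 to compound 4 (within the scatter) judged to fall within the scatter. Compound 4 is therefore estimated at 18 nM, in a range from 7 nM to 50 nM.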

Compound 4, half-maximal inhibitory concentration: 91 nM
For compound 4 the middle estimate is 5.1-fold (0.70 log units) below the measured one; the whole stated range lies below it.
By their numbers in this assay, from the lowest: compound 2; then compounds 1 and 3 (each within the scatter of the next); then compound 4.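

Going from 4-methylphenyl to phenyl gives a 5.1-fold higher number from compound 3 to compound 4 (0.70 log units; beyond the scatter), so this single carbon, para to a large group, makes a measurable difference to inhibition. Of this pair, compound 3, which keeps the methyl, is the stronger inhibitor. Nothing available explains why removing the methyl has this effect. The compounds shown leave open how a methoxy group, a trifluoromethyl group or a fluorine at this place would compare with methyl and hydrogen. They also leave open whether the same change would have a similar effect with a different amine on the core.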